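The source may hold more compounds than are shown below. What is called first, only, known or untested is meant among the compounds shown, and "the series" means these compounds.

Compound 1, `COc1ccc([C@H]2CC(=O)N(c3cc(N)cc(N)c3)C2)cc1OC1CCCC1`: in a functional assay on HEK293 cells (Homo sapiens) for cytotoxicity (a higher number here means that more compound is tolerated, a lower number that less compound is tolerated), compound 1 gives > 10000 nM, which is a limit of the assay rather than a number.
Compound 2, `COc1ccc([C@H]2CC(=O)N(c3cc(N)cc(F)c3)C2)cc1OC1CCCC1`: in this assay compound 2 gives > 10000 nM, again a limit.
Compound 3, `CCCCNc1cccc(N2C[C@@H](c3ccc(OC)c(OC4CCCC4)c3)CC2=O)c1`: in this assay compound 3 gives > 10000 nM, also a limit.

All three compounds share the same core and all three sit at the limit of > 10000 nM in this assay, at which 3 of the 3 values shown sit, so none of them can be placed above or below another; compound 3 stands exactly where the other two do. Among the measured compounds shown here, the only one-place step among them, a step that the two limits leave unreadable from compound 1 to compound 2, is unreadable since both of its ends are limits.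

Compound 4, `COc1ccc([C@H]2CC(=O)N(c3cccc(NS(=O)(=O)c4ccccc4Br)c3)C2)cc1OC1CCCC1`, differs from compound 3 by (2-bromophenyl)sulfonyl in place of butyl on a nitrogen on an aromatic ring. For the measured compounds named here, no measured step bears directly on this change: the one step that exists, from compound 1 to compound 2, concerns a different position and its size cannot be read. Going by the values given here, with every value so far resting at the limit of > 10000 nM in this assay, at which 3 of the 3 values shown sit, compound 4 is expected to stay at that limit as well, although a readable number cannot be excluded. Compound 4 is therefore estimated at 10000 nM, with a range from 3000 nM to 30000 nM. The expected step of a number no higher from compound 3 to compound 4 (the limit leaves the size open) is none beyond the usual scatter.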

Compound 4, half-maximal cytotoxic concentration: > 10000 nM
Compound 4 gave a limit, no number; the forecaster's own chance of this, stated with the estimate: 70%; the middle value lies on the limit itself.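

Compound 3 and compound 4 both give a limit rather than a number in this assay, so no step can be read between them, and the size of the change from butyl to (2-bromophenyl)sulfonyl stays unknown: the limit of > 10000 nM in this assay, at which 4 of the 4 values shown sit.

The compounds shown leave open what concentration of any of them harms these cells, and whether any change to the shared core would give a readable number.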